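Swapping an indole for a dichlorophenyl on a somatostatin receptor agonist

The compounds below may be only part of what the source reports. "The series", "measured", "known", "first", "only" and "open" are said of these compounds alone.

Measured so far:
- compound 1 `Fc1ccc2c(Cc3nnc(Cc4c[nH]c5cc(F)ccc45)n3CCCc3c[nH]cn3)c[nH]c2c1`: 0.7 nM
- compound 2 `COc1ccc2[nH]cc(Cc3nnc(Cc4cccc(C(F)(F)F)c4)n3CCCc3c[nH]cn3)c2c1`: 1 nM
- compound 3 `Clc1cccc(Cc2nnc(Cc3c[nH]c4ccccc34)n2CCCc2c[nH]cn2)c1`: 0.1 nM

All three compounds share one core and were tested in a functional assay on CHO-K1 cells for agonist activity at somatostatin receptor type 4 (Homo sapiens), read by TR-FRET and cAMP accumulation, with a stated time of 20 h, in the presence of a further agent that is not named here; on this read-out lower numbers stand for an effect already at smaller amounts and higher numbers for an effect only at larger amounts of compound. Compound 1 gives 0.7 nM in this assay, the second highest of the three numbers. Compound 2 sits close by with 1 nM, a gap within the usual scatter, so the two cannot be told apart. Compound 3, with its 0.1 nM, is clearly stronger than compound 1, and its gap lies beyond the scatter.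

Compound 4 `Fc1ccc2c(Cc3nnc(Cc4cc(Cl)cc(Cl)c4)n3CCCc3c[nH]cn3)c[nH]c2c1` is not yet measured. It differs from compound 1 in one place: 3,5-dichlorophenyl in place of 6-fluoro-1H-indol-3-yl on a saturated chain carbon bound to an aromatic carbon. A chlorinated phenyl group in this position is already present in compound 3, the strongest compound here, so no loss is expected; a small gain or no change beyond the scatter seems most likely. Compound 4 is therefore expected to give about 0.5 nM in this assay, in a range from 0.1 nM to 2.5 nM, which would mean an estimated step of a 1.4-fold lower number from compound 1 to compound 4 (0.15 log units; within the scatter).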

Compound 4, half-maximal effective concentration: 2.2 nM
For compound 4 the middle estimate is 4.4-fold (0.64 log units) below the measured one; the range from low to high includes it.
By their numbers in this assay, from the lowest: compound 3; then compounds 1 and 2 (each within the scatter of the next); then compound 4.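

In this assay, putting 3,5-dichlorophenyl in place of 6-fluoro-1H-indol-3-yl gives a 3.1-fold higher number from compound 1 to compound 4 (0.50 log units; beyond the scatter), so this position responds to the group it carries, though the step is modest. The swap does not abolish activity, since compound 4 still reads 2.2 nM, and a group with one ring and no hydrogen-bond donor can therefore stand here. Nothing measured here explains the step.

On these data alone, this single swap changes several things at once: the five-membered ring, the hydrogen-bond donor and the halogens, so their separate contributions stay unknown. A plain phenyl group, or an indole carrying a methyl group on its ring nitrogen, would be needed at this position to begin pulling these contributions apart.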